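The source may report more compounds than this note shows. Statements on the series, on what has been measured and on what is new or still open speak of the compounds shown alone.

Compound 1 `Cc1nc(NC(=O)c2ccccc2)sc1C(=O)/C=C/c1ccccc1` gives 73.5% in an assay for inhibition of Polyunsaturated fatty acid 5-lipoxygenase (Homo sapiens), read by spectrophotometry, tested at 10 uM, in the presence of a further agent that is not named here; on this read-out lower numbers stand for less inhibition and higher numbers for more inhibition at the one concentration tested (going by the name of the read-out). Compound 2 `Cc1nc(NC(=O)c2ccccc2)sc1C(=O)/C=C/c1ccc(F)cc1` carries fluoro in place of hydrogen on an aromatic carbon and gives 98% in this assay, a step of a number 24.5 percentage points higher from compound 1 to compound 2 (beyond the scatter). Compound 3 `Cc1nc(NC(=O)c2ccccc2)sc1C(=O)/C=C/c1cccs1` differs from compound 1 by thiophen-2-yl in place of phenyl on a double-bonded chain carbon bound to a double-bonded chain carbon; in this assay compound 3 gives 71.9%. The step of a number 1.6 percentage points lower from compound 1 to compound 3 (within the scatter) is small, while the step of a number 26.1 percentage points lower from compound 2 to compound 3 (beyond the scatter) is clearer. Compound 4 `Cc1nc(NC(=O)c2ccc(F)cc2)sc1C(=O)/C=C/c1cccs1` has not been measured in this assay; it differs from compound 3 by fluoro in place of hydrogen on an aromatic carbon, the same change at the same place as from compound 1 to compound 2, though on a core that differs by thiophen-2-yl in place of phenyl on a double-bonded chain carbon bound to a double-bonded chain carbon. Among the compounds with values here, because a number 24.5 percentage points higher from compound 1 to compound 2 (beyond the scatter) was the only earlier step of this kind, compound 4 is expected to gain a number 18.1 percentage points higher from compound 3 to compound 4 (beyond the scatter), and its value in this assay is estimated at 90%, between 72% and 100%.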

Compound 4, a percentage reported as inhibition, at one concentration (the size of the read-out at that concentration, not a potency): 81.7%
Estimate against measurement, compound 4: 8.3 percentage points above; the range from low to high includes it.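

On the evidence of this assay, fluoro in place of hydrogen does not carry over from one core to the other at the same size: the same change on two cores in this assay, a number 24.5 percentage points higher (beyond the scatter) from compound 1 to compound 2 and a number 9.8 percentage points higher (within the scatter) from compound 3 to compound 4, 14.7 percentage points apart, beyond the scatter of two such steps On the core of compound 3, the change gives a number 9.8 percentage points higher from compound 3 to compound 4 (within the scatter), so there it cannot be told apart from no change. These two pairs show that the gain seen on the core of compound 1 cannot simply be transferred, but they do not show how the change would behave on any other core.

The compounds shown leave open how a chloro, a methoxy or an amine would compare with fluoro. They also leave open what a longer chain in place of the methyl on the shared core would do.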